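This account rests on a few compounds, and the source may have more. Where it says the series, first, only, none or still open, it means among the compounds named here.

Compound 1 `CC(C)c1ccc(-c2nc(SCc3cn(CC(=O)NC(=O)Nc4ccccn4)nn3)nc(Nc3ccc(Cl)cc3)c2C#N)cc1` was tested in a functional assay on MCF7 cells (Homo sapiens) for inhibition, read by MTT assay, with a stated time of 72 h (a lower number here means a stronger inhibitor, a higher number a weaker inhibitor), and for compound 1 the result is only a limit of the assay, > 64000 nM. Compound 2 `CC(C)c1ccc(-c2nc(SCc3cn(CC(=O)NC(=O)Nc4ccccn4)nn3)nc(Nc3ccccc3)c2C#N)cc1` differs from compound 1 by hydrogen in place of chloro on an aromatic carbon. In this assay compound 2 also gives only a limit, > 64000 nM. The step that the two limits leave unreadable from compound 1 to compound 2 therefore cannot be read in size, because the limit of > 64000 nM in this assay, at which 2 of the 3 values shown sit, is where both values sit.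

Compound 3 `Cc1ccc(Nc2nc(SCc3cn(CC(=O)NC(=O)Nc4ccccn4)nn3)nc(-c3ccc(Cl)cc3)c2C#N)cc1` is built on a different core, and the difference between the two cores is not broken down here. In this assay, for the measured compounds named here, compound 3 gives 27000 nM, the only true number among the three measured compounds.

Compound 4 `Cc1ccc(Nc2nc(SCc3cn(CC(=O)NC(=O)Nc4ccccn4)nn3)nc(-c3ccccc3)c2C#N)cc1` has not yet been measured. It differs from compound 3 by hydrogen in place of chloro on an aromatic carbon. This is the same kind of change as that from compound 1 to compound 2, but the place is not identical: in compound 1 the ring that loses the chloro is the one described as (4-chlorophenyl)amino becoming anilino, while in compound 3 the ring is the 4-chlorophenyl attached directly to the core. The earlier step gives no readable size, so it offers no guide to the size expected here. Working from the value of compound 3, 27000 nM, the step from compound 3 to compound 4 is expected to be small, a 1.3-fold higher number from compound 3 to compound 4 (0.11 log units; within the scatter), and compound 4 is estimated at 35000 nM, within 10000 nM to 90000 nM.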

Compound 4, half-maximal inhibitory concentration: > 64000 nM
Compound 4 was reported as a limit (the forecaster's own chance of this, stated with the estimate: 40%); middle value at least 1.8-fold (0.26 log units) away from the limit.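

In this assay, the change from 4-chlorophenyl to phenyl gives an at least 2.3-fold higher number from compound 3 to compound 4 (0.37 log units; beyond the scatter), so on this core, losing the chloro weakens the result by more than the usual scatter. From the compounds shown here alone, compound 4 is reported only as a limit, so the full size of this step remains unknown. The step cannot be compared with the same kind of change on the core of compound 1, where the chloro also sits on a different ring, and whether the effect carries from one core to the other stays unanswered because both values for that pair sit at the same limit: the limit of > 64000 nM in this assay, at which 3 of the 4 values shown sit.

With only compound 3 giving a true number, the series offers a single readable step, and that step rests on one pair of compounds, so it sets no rule for the series. Going by these compounds, it remains open how other groups would behave at the place that held the chloro, such as a methoxy group, an amine or a carboxylic acid, and whether a longer chain in the shared side chain would change the result on either core.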